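Ester chain length versus cytotoxicity: compounds 2 and 3

This account rests on a few compounds, and the source may have more. Where it says the series, first, only, none or still open, it means among the compounds named here.

Compound 2 `CCCCCCCCCCCCOC(=O)CCC(=O)N1CCN(CCCOc2cc3c(Nc4ccc(F)c(Cl)c4)ncnc3cc2OC)CC1` stands level with its only comparator: in a functional assay on A549 cells (Homo sapiens) for cytotoxicity, read by MTT assay, with a stated time of 24 h, tested at 20 uM (a lower number here means a stronger effect, a higher number a weaker effect of the compound at the concentration tested), compound 2 gives 86.8%, and compound 1 `CCCCOC(=O)CCC(=O)N1CCN(CCCOc2cc3c(Nc4ccc(F)c(Cl)c4)ncnc3cc2OC)CC1` gives 86%, two numbers indistinguishable within the scatter. Both figures sit high, meaning a weak effect at the concentration tested, and neither compound can be called more or less active than the other.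

Among the measured compounds shown here, the single measured step, a number 0.8 percentage points higher from compound 1 to compound 2 (within the scatter), is the only one that bears on the next change. Compound 3 `CCCCCCCCCCCCCCCCCCCOC(=O)CCC(=O)N1CCN(CCCOc2cc3c(Nc4ccc(F)c(Cl)c4)ncnc3cc2OC)CC1` differs from compound 2 by heptyl in place of hydrogen on a saturated chain carbon, ten or more bonds along the chain from an oxygen next to a carbonyl group. This is a further extension of the same saturated chain, cut further out along it, and the earlier extension, a number 0.8 percentage points higher from compound 1 to compound 2 (within the scatter), produced nothing beyond the scatter. With no other data on this chain, no step beyond the scatter is expected in either direction. The step expected is a number 0.2 percentage points higher from compound 2 to compound 3 (within the scatter), essentially flat. Compound 3 is therefore expected to give about 87% in this assay, with a range from 76% to 97%.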

Compound 3, a percentage reported as activity, at one concentration (the size of the read-out at that concentration, not a potency): 94.8%
Compound 3: the middle estimate sits 7.8 percentage points below what was measured; low and high end bracket the measured number.
By their numbers in this assay, from the lowest: compounds 1, 2 and 3 (each within the scatter of the next).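

In this assay, heptyl in place of hydrogen on a saturated chain carbon, ten or more bonds along the chain from an oxygen next to a carbonyl group, amounts to a number 8 percentage points higher from compound 2 to compound 3 (within the scatter), so even this far out along the chain the change does not give a step beyond the scatter. Read with a number 0.8 percentage points higher from compound 1 to compound 2 (within the scatter), it leaves both listed extensions of this saturated chain within the scatter, and compound 3, at 94.8%, stays high on a scale where a high number means a weak effect at the concentration tested. Nothing measured on these compounds accounts for this result.

The compounds shown vary only the length of a saturated chain, so it remains open whether a terminal amine or a carboxylic acid at the far end of the chain, or a much shorter chain such as methyl, would give a step beyond the scatter. From the compounds shown here alone, with a single concentration and high numbers throughout, it also remains open whether any real difference would appear at other concentrations.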